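Bromo for Chloro in a Series Without Measurable Effect

The source may report more compounds than this note shows. Statements on the series, on what has been measured and on what is new or still open speak of the compounds shown alone.

Compound 1, `COc1ccccc1NC(=O)NC1CC(C)(C)Oc2ccc(Cl)cc21`, is reported in a functional assay (aorta) with Rattus norvegicus as the target (on this read-out higher numbers stand for an effect only at larger amounts of compound and lower numbers for an effect already at smaller amounts), only as a limit, > 10000 nM.
Compound 2, `COc1ccccc1NC(=O)NC1CC(C)(C)Oc2ccc(Br)cc21`, is likewise reported only as a limit, > 10000 nM.
Compound 3, `Cc1ccc(NC(=O)NC2CC(C)(C)Oc3ccc(Cl)cc32)cc1`, is reported only as a limit, > 30000 nM.

The change bromo in place of chloro on an aromatic carbon gives a step that the two limits leave unreadable from compound 1 to compound 2. The two cores differ by 4-methylphenyl in place of 2-methoxyphenyl on an amide-type nitrogen, which gives a step that the two limits leave unreadable from compound 1 to compound 3. Two of the three values sit at the limit of > 10000 nM in this assay, at which 2 of the 3 values shown sit, and one at the limit of > 30000 nM in this assay, at which 1 of the 3 values shown sits.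

Compound 4, `Cc1ccc(NC(=O)NC2CC(C)(C)Oc3ccc(Br)cc32)cc1`, carries the same change as compound 2, namely (bromo in place of chloro on an aromatic carbon). Since both measured members of this pair return only limits, the step is expected to be a number no higher from compound 3 to compound 4 (the limit leaves the size open), and compound 4 is estimated at 30000 nM in this assay, most probably again reported only as a limit.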

Compound 4, half-maximal effective concentration: > 30000 nM
Compound 4: a limit, no number; the forecaster's own chance of this, stated with the estimate: 85%; the middle value sits exactly at the limit.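

Compound 4 is again reported only as a limit, so no step can be read from compound 3 or compound 2 to it. The compounds shown leave open whether bromo in place of chloro, or 4-methylphenyl in place of 2-methoxyphenyl, changes the effect at all.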